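A Benzyl Swap on Compound 1 with No Measured Anchor

The compounds below may be only part of what the source reports. "The series", "measured", "known", "first", "only" and "open" are said of these compounds alone.

Compound 1 `Nc1cc(N)c2nc(-c3ccccc3)c(NCc3ccc(Cl)c(Cl)c3)nc2c1` was examined in a functional assay on SNB-19 cells (Homo sapiens) for inhibition, read by sulforhodamine B assay, with a stated time of 48 h; on this read-out lower numbers stand for higher toxicity in this test and higher numbers for lower toxicity in this test. In this assay compound 1 gives < 100000 nM, which is a limit of the assay and not a number. Two further compounds on the same core were run alongside it. Compound 2 `CCOC(=O)[C@H](CCC(=O)O)NC(=O)c1ccc(Sc2nc3cc(N)cc(N)c3nc2-c2ccccc2)cc1` in this assay gives < 100000 nM, again a limit rather than a number. Compound 3 `COc1cc(CNc2nc3cc(N)cc(N)c3nc2-c2ccccc2)cc(OC)c1OC` in this assay gives < 50200 nM, also a limit. The picture is therefore summarised by the limit of < 100000 nM in this assay, at which 2 of the 3 values shown sit, and by the limit of < 50200 nM in this assay, at which 1 of the 3 values shown sits: compound 1 stands at one of these limits, and the numbers shown do not separate the three compounds at all.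

The unmeasured compound 4 `Nc1cc(N)c2nc(-c3ccccc3)c(NCc3ccc(F)cc3)nc2c1` differs from compound 1 in one place: 4-fluorophenyl in place of 3,4-dichlorophenyl on a saturated chain carbon bound to a nitrogen on an aromatic ring. Going by the values given here, no step between measured compounds is available, so nothing shows how far a change of this kind moves the read-out. On that basis the expected step in this assay is a step that the limit leaves unreadable from compound 1 to compound 4, none beyond the scatter. For compound 4 the estimate in this assay is 60000 nM, expected to fall between 15000 nM and 100000 nM, with a limit rather than a number seen as the likelier report.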

Compound 4, concentration lethal to 50% of the cells: 52500 nM
Compound 4: the middle estimate sits 1.1-fold (0.06 log units) above what was measured, and the stated range covers the measured number.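

In this assay compound 1 gives < 100000 nM and that is a limit of the assay and not a number. In this assay, going by these compounds alone, compound 4 gives 52500 nM as a measured number, and no step from compound 1 to compound 4 can be read. The compounds shown leave open how far the change from 3,4-dichlorobenzyl to 4-fluorobenzyl moves this read-out.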